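The source may report more compounds than this note shows. Statements on the series, on what has been measured and on what is new or still open speak of the compounds shown alone.

Three compounds have so far been examined in an ADME assay on Vero cells (Chlorocebus sabaeus) for cytotoxicity; a higher number here means a weaker inhibitor, a lower number a stronger inhibitor. Compound 1 `CC(=O)O[C@H]1C=CC=C[C@@]1(O)COC(=O)c1ccccc1` gives only a limit, > 50000 nM. Compound 2 `CC(=O)O[C@H]1C=C[C@@H](O)[C@H](O)[C@@]1(O)COC(=O)c1ccccc1` likewise gives only a limit, > 50000 nM. Compound 3 `CC(=O)O[C@H]1C=C[C@@H](Cl)[C@@](O)(COC(=O)c2ccccc2)[C@@H]1O` also returns only a limit, > 50000 nM. Compound 3 thus stands exactly where the other two sit: the limit of > 50000 nM in this assay, at which 3 of the 3 values shown sit. For the measured compounds named here, no step between measured compounds that differ in one place is available.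

Compound 4 `O=C(OC[C@]1(O)[C@H](Cl)C=C[C@H](O)[C@H]1O)c1ccccc1` differs from compound 3 in one place: hydrogen in place of acetyl on an oxygen on a saturated carbon. Seen one bond further out, an acetoxy becomes a hydroxy. The step that the limit leaves unreadable from compound 3 to compound 4 is expected to be none beyond the scatter, with a limit again the likeliest outcome. Compound 4 is therefore estimated at about 100000 nM, between 40000 nM and 300000 nM.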

Compound 4, half-maximal inhibitory concentration: > 50000 nM
Compound 4 gave a limit, no number (the forecaster's own chance of this, stated with the estimate: 85%); the middle value is on the limit's open side.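

For the compounds shown here, compound 3 and compound 4 both give only a limit in this assay, so no step between them can be read: the limit of > 50000 nM in this assay, at which 4 of the 4 values shown sit. None of the compounds shown carries a number, which leaves open how far any structural change moves the read-out.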